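The source may hold more compounds than are shown below. What is called first, only, known or untested is meant among the compounds shown, and "the series" means these compounds.

Three compounds share one core and differ only in the group carried on an aromatic carbon of a six-membered carbon ring. Compound 1 `COc1ccc(-c2cncc(C(=O)N(C)C)c2)cc1S(=O)(=O)Nc1cccc(NCCNC(=O)c2cccc(C)c2)c1` gives 7530 nM in a functional assay on CHO-RD-HGA16 cells for agonist activity at Orexin/Hypocretin receptor type 1 (Homo sapiens), read by fluorescence and calcium flux, with a stated time of 30 min; a lower number here means that less compound is needed, a higher number that more compound is needed for the effect. Compound 2 `COc1ccc(-c2cccc(C(=O)N(C)C)n2)cc1S(=O)(=O)Nc1cccc(NCCNC(=O)c2cccc(C)c2)c1` gives 226 nM in this assay. Compound 3 `COc1ccc(-c2csc(C(=O)N(C)C)c2)cc1S(=O)(=O)Nc1cccc(NCCNC(=O)c2cccc(C)c2)c1` gives 1330 nM in this assay, the second highest of the three numbers. The two steps that lead to it are a 5.7-fold lower number from compound 1 to compound 3 (0.75 log units; beyond the scatter) and a 5.9-fold higher number from compound 2 to compound 3 (0.77 log units; beyond the scatter), so each swap of the ring at this spot moved the number by a modest amount, while a 33-fold lower number from compound 1 to compound 2 (1.52 log units; beyond the scatter) shows that a swap here can also move it a great deal.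

Compound 4 `COc1ccc(CCC(=O)N(C)C)cc1S(=O)(=O)Nc1cccc(NCCNC(=O)c2cccc(C)c2)c1` is made by the change (2-(dimethylcarbamoyl)ethyl in place of 5-(dimethylcarbamoyl)thiophen-3-yl on an aromatic carbon). Among the compounds with values here, none of the measured steps replaces a ring with an open chain, so they show only that this spot matters, not which way a chain would pull. The step expected in this assay is a modest rise, a 3.0-fold higher number from compound 3 to compound 4 (0.48 log units; beyond the scatter). Compound 4 is therefore estimated at 4000 nM, within a range from 1000 nM to 20000 nM.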

Compound 4, half-maximal effective concentration: > 10000 nM
Compound 4 gave a limit, no number; the forecaster's own chance of this, stated with the estimate: 10%; middle value at least 2.5-fold (0.39 log units) away from the limit.
By their numbers in this assay, from the lowest: compound 2; then compound 3; then compound 1. At a limit, above all of these: compound 4.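

Compound 4 gave a limit and not a number: the limit of > 10000 nM in this assay, at which 1 of the 4 values shown sits. Even so, the limit shows that this position tolerates the open chain poorly, since 2-(dimethylcarbamoyl)ethyl in place of a ring gives an at least 7.5-fold higher number from compound 3 to compound 4 (0.87 log units; beyond the scatter) and an at least 44-fold higher number from compound 2 to compound 4 (1.64 log units; beyond the scatter), the second being large. Against the weakest ring compound the floor is too small to separate the two, with an at least 1.3-fold higher number from compound 1 to compound 4 (0.12 log units; that floor lies within the scatter), so among these compounds the ring-free chain clearly loses only to the thiophene and the 6-(dimethylcarbamoyl)pyridin-2-yl group.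

On these data alone, the true value of compound 4 remains unknown, and so does whether it really differs from compound 1. As far as these compounds go, it is also open whether a longer chain, or a chain ending in an amine or a carboxylic acid instead of the dimethylcarbamoyl group, would fare any better at this position.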